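This account rests on a few compounds, and the source may have more. Where it says the series, first, only, none or still open, it means among the compounds named here.

Measured so far: compound 1 `CC(CCc1cccc(OCc2ccc3ccccc3n2)c1)Cc1nnn[nH]1` with 17 nM in an assay on membranes from lung (Cavia porcellus) for binding affinity to cysteinyl leukotriene receptor (Homo sapiens); on this read-out lower numbers stand for stronger inhibition and higher numbers for weaker inhibition; compound 2 `CC(CCc1nnn[nH]1)Cc1cccc(OCc2ccc3ccccc3n2)c1` with 34 nM in this assay.

Compound 2 has the higher of the two numbers, but a 2.0-fold higher number from compound 1 to compound 2 (0.30 log units; within the scatter) is within the scatter, so the two are not told apart.

Compound 3 `CCCC(CCC(=O)O)Cc1cccc(OCc2ccc3ccccc3n2)c1` is unmeasured. It differs from compound 2 by 1-(2-carboxyethyl)butyl in place of 3-(1H-tetrazol-5-yl)-1-methylpropyl on a saturated chain carbon bound to an aromatic carbon. Among the compounds with values here, no measured step covers this swap; the only step in hand, a 2.0-fold higher number from compound 1 to compound 2 (0.30 log units; within the scatter), moves the tetrazole along the chain and stays within the scatter. With nothing bearing on the acid for the tetrazole, compound 3 is expected to land near compound 2, estimate 60 nM (range 15 nM to 250 nM), a step of a 1.8-fold higher number from compound 2 to compound 3 (0.25 log units; within the scatter) in this assay that may well be within the scatter.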

Compound 3, inhibition constant: 50 nM
For compound 3 the middle estimate is 1.2-fold (0.08 log units) above the measured one; measured number inside the range.
By their numbers in this assay, from the lowest: compounds 1, 2 and 3 (each within the scatter of the next, the first and the last beyond it).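

In this assay, 1-(2-carboxyethyl)butyl on the saturated chain carbon bound to an aromatic carbon gives a 1.5-fold higher number from compound 2 to compound 3 (0.17 log units; within the scatter) and so is not told apart from the 3-(1H-tetrazol-5-yl)-1-methylpropyl chain. Set against 2-((1H-tetrazol-5-yl)methyl)propyl, the same group gives a 2.9-fold higher number from compound 1 to compound 3 (0.47 log units; beyond the scatter) as the only step in the series beyond the scatter. Nothing in hand accounts for the size of either step.

As far as these compounds go, the tetrazole and the chain change together in both steps, so their separate contributions remain open. From the compounds shown here alone, how a primary amide or a sulfonamide would read at this end of the chain is also open.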